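The source may hold more compounds than are shown below. What is called first, only, known or untested is meant among the compounds shown, and "the series" means these compounds.

Working notes on the series. Compound 1 `Cn1cc(-c2cnc(NCc3c(F)ccc4c3CCO4)c3cn[nH]c(=O)c23)cn1` carries the shared core with a 1-methyl-1H-pyrazol-4-yl group. Within the data shown here, in a physicochemical assay for lipophilicity, using the shake flask method, in phosphate buffer, measured as octanol-water partition, with a stated time of 30 min, at pH 7.4 (a higher number here means a more lipophilic compound, a lower number a more polar compound), compound 1 gives 2.7, the higher of the two numbers measured so far. Compound 2 `CN(C)Cc1ccc(C(=O)Nc2cnc(NCc3c(F)ccc4c3CCO4)n3cnnc23)cc1` is built on a different core and in this assay compound 2 gives 1.8, a value that lies below compound 1 by more than the scatter. The two compounds differ in several places at once, so the pair says nothing about any single change.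

Compound 3 `Cc1cc(-c2cnc(NCc3c(F)ccc4c3CCO4)c3cn[nH]c(=O)c23)n(C)n1` is the next compound to be measured in this assay. It differs from compound 1 in one place: 1,3-dimethyl-1H-pyrazol-5-yl in place of 1-methyl-1H-pyrazol-4-yl on an aromatic carbon. Among the measured compounds shown here, no measured pair in the set isolates this change, so the expectation rests on the change itself and on compound 1 at 2.7. A small upward step is expected here, a number 0.30 log units higher from compound 1 to compound 3 (within the scatter), hardly beyond the scatter. Compound 3 is expected to give 3 in this assay, with a range from 2.6 to 3.5.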

Compound 3, distribution coefficient: 3
Estimate against measurement, compound 3: no gap at the digits printed; the measured number falls inside the stated range.
By their numbers in this assay, from the lowest: compound 2; then compounds 1 and 3 (each within the scatter of the next).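

In this assay, among these compounds, the replacement of 1-methyl-1H-pyrazol-4-yl by 1,3-dimethyl-1H-pyrazol-5-yl on this aromatic carbon gives the first step that isolates a single place, a number 0.30 log units higher from compound 1 to compound 3 (within the scatter), so the two groups cannot be told apart on this read-out. The entering group has 7 heavy atoms in place of 6, while the ring type, the 0 hydrogen-bond donors and the 2 hydrogen-bond acceptors stay as they were, and this difference in size leaves no reading beyond the scatter at this position. No supporting measurement bears on the result, so it stands as an observation without an explanation.

The two group names differ both in the added methyl and in the point of attachment of the pyrazole, and this one step cannot separate those two features. Also open, going by these compounds, is how the number responds on this aromatic carbon to a group of another kind, such as an amine, a carboxylic acid or a longer alkyl chain, since both groups compared here are methylated pyrazoles.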